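Notes on the step from compound 3 to compound 4

This account rests on a few compounds, and the source may have more. Where it says the series, first, only, none or still open, it means among the compounds named here.

Measured compounds in an ADME assay on THP-1 cells (Homo sapiens) for cytotoxicity, read by MTT assay, with a stated time of 72 h; a lower number here means that less compound is needed, a higher number that more compound is needed for the effect (each entry is a limit and not a number)
- compound 1 `Cc1cncc(-c2ccc3[nH]c(=O)nc(-c4ccccc4)c3c2)c1`: > 50000 nM
- compound 2 `N#Cc1ccc(-c2ccc3[nH]c(=O)nc(-c4ccccc4)c3c2)cc1`: > 50000 nM
- compound 3 `Cn1cc(-c2ccc3[nH]c(=O)nc(-c4ccccc4)c3c2)cn1`: > 50000 nM

Compound 3 stands only at a limit (> 50000 nM). The whole set shares that position (the limit of > 50000 nM in this assay, at which 3 of the 3 values shown sit).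

Compound 4 `Cn1nccc1-c1ccc2[nH]c(=O)nc(-c3ccccc3)c2c1` has the same atoms as compound 3, joined differently, with 1-methyl-1H-pyrazol-5-yl in place of 1-methyl-1H-pyrazol-4-yl on an aromatic carbon.

For the measured compounds named here, two measured steps touch this position (a step that the two limits leave unreadable from compound 1 to compound 3; a step that the two limits leave unreadable from compound 2 to compound 3). A third changes the same place (a step that the two limits leave unreadable from compound 1 to compound 2). None of the three has a readable size, so the series offers no measured size for this change.

The expectation therefore rests on the limit of compound 3 (> 50000 nM). No step beyond the scatter, in either direction, is expected in this assay (a number no higher from compound 3 to compound 4 (the limit leaves the size open)). Compound 4 is estimated at 50000 nM (expected range 20000 nM to 100000 nM), most likely reported again as a limit.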

Compound 4, half-maximal effective concentration: > 50000 nM
Compound 4: a limit, no number; the forecaster's own chance of this, stated with the estimate: 85%; the middle value sits exactly at the limit.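

In this assay compound 4 gives > 50000 nM, a limit and not a number. Its steps from compound 1, compound 2 and compound 3 cannot be read. The compounds shown leave open what concentration of any of them reaches the half-maximal effect, and whether these replacements on the shared core change it at all: the limit of > 50000 nM in this assay, at which 4 of the 4 values shown sit.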